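Methylsulfanyl for methoxy on the aryl ring of compound 3

The compounds below may be only part of what the source reports. "The series", "measured", "known", "first", "only" and "open" are said of these compounds alone.

Measured compounds:
- compound 1 `CCOC(=O)C1=C(C)NC(=S)NC1c1ccc(O)c(O)c1`: 25 ug/mL
- compound 2 `CCOC(=O)C1=C(C)NC(=O)NC1c1ccc(O)c(O)c1`: 1.6 ug/mL
- compound 3 `CCOC(=O)C1=C(C)NC(=S)NC1c1ccc(OC)cc1`: 0.99 ug/mL

Of the compounds shown here, three sharing one core have been tested in a functional assay on OVCAR-3 cells (Homo sapiens) for inhibition, read by sulforhodamine B assay, with a stated time of 48 h; a lower number here means a stronger inhibitor of growth, a higher number a weaker inhibitor of growth. Compound 1 gives 25 ug/mL in this assay, and compound 2 gives 1.6 ug/mL. Compound 3 gives the lowest of the three numbers, 0.99 ug/mL, but compound 2 stands within the scatter of it, so the two cannot be ranked against each other; only compound 1 stands clearly apart, with a number beyond the scatter above that of compound 3.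

Compound 4 `CCOC(=O)C1=C(C)NC(=S)NC1c1ccc(SC)cc1` has not yet been measured. It differs from compound 3 in one place: methylsulfanyl in place of methoxy on an aromatic carbon. Within the data shown here, no measured pair here shows the effect of such an exchange, so the expectation rests only on the closeness of the two groups as counted. For compound 4 the step from compound 3 is expected to be none beyond the scatter, in either direction, as a 1.2-fold higher number from compound 3 to compound 4 (0.08 log units; within the scatter). Compound 4 is therefore estimated at 1.2 ug/mL in this assay, with a range from 0.35 ug/mL to 4 ug/mL that allows the number to drift either way once it is measured.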

Compound 4, concentration for 50% growth inhibition: 8.5 ug/mL
Beside the measured number, compound 4's estimate is 7.1-fold (0.85 log units) below it; the measured number lies above the stated range.
By their numbers in this assay, from the lowest: compounds 3 and 2 (each within the scatter of the next); then compound 4; then compound 1.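

In this assay, among these compounds, methylsulfanyl in place of methoxy on the aromatic carbon gives an 8.6-fold higher number from compound 3 to compound 4 (0.93 log units; beyond the scatter), the first step that isolates this position, which the earlier compounds could not do. The two groups match in everything counted here: each has two heavy atoms, no ring, no hydrogen-bond donor, one hydrogen-bond acceptor and no net charge, and they differ in that sulfur stands where oxygen stood. So this aromatic carbon, para to a large group, is not indifferent to the exchange, even though the counted features stay the same, and nothing measured here explains the shift.

Going by these compounds, one step on one aromatic carbon gives no trend, so it remains open whether a chlorine atom, a dimethylamino group or a longer chain such as ethoxy would leave the number close to that of compound 3 or raise it further. On these data alone, it also remains open whether the same exchange of methoxy for methylsulfanyl would produce a step of similar size on a differently substituted aromatic ring.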